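Trading the hydroxycarbamoyl end of compound 2 for an amide

The source may hold more compounds than are shown below. What is called first, only, known or untested is meant among the compounds shown, and "the series" means these compounds.

Within the data shown here, in a functional assay on MCF7 cells (Homo sapiens) for inhibition, read by MTT assay, with a stated time of 72 h (a higher number here means a weaker inhibitor, a lower number a stronger inhibitor), compound 2 `Nc1nc2cc(-c3nn(CCCCC(=O)NO)c4ncnc(N)c34)ccc2o1` gives 14000 nM, the only exact number so far. Compound 1 `Nc1ncnc2c1c(-c1cnc3[nH]ccc3c1)nn2CCCCC(=O)NO` gives only a limit, > 150000 nM. Compound 3 `CNC(=O)CCCCCCCn1nc(-c2ccc3oc(N)nc3c2)c2c(N)ncnc21` has not yet been measured. It carries 3-(methylcarbamoyl)propyl in place of hydroxycarbamoyl on a saturated chain carbon, four bonds along the chain from an aromatic nitrogen. Among the measured compounds shown here, no measured pair shows a change of this kind, so the expectation is loose: a moderate weakening, estimated as a 3.2-fold higher number from compound 2 to compound 3 (0.51 log units; beyond the scatter). In this assay, compound 3 is expected at 45000 nM, with an estimated range from 12000 nM to 150000 nM.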

Compound 3, half-maximal inhibitory concentration: 7220 nM
Compound 3: middle estimate off by 6.2-fold (0.79 log units), on the high side; the whole stated range lies above it.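

Replacing hydroxycarbamoyl with 3-(methylcarbamoyl)propyl at this place gives a 1.9-fold lower number from compound 2 to compound 3 (0.29 log units; within the scatter) in this assay. Within this one pair, then, the hydroxycarbamoyl end is not required for activity in the cells: the longer chain ending in a methyl amide keeps the reading level with compound 2. Nothing measured here offers a cause for this result.

Chain length and end group change together in this step, so their separate contributions remain open. A carboxylic acid or an amine at the chain end would show how much the end group itself matters.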